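The source may report more compounds than this note shows. Statements on the series, on what has been measured and on what is new or still open speak of the compounds shown alone.

For the measured compounds named here, in a physicochemical assay for lipophilicity, using the shake flask method, at pH 7.4 (on this read-out higher numbers stand for higher lipophilicity and lower numbers for lower lipophilicity), compound 1 `CCCC(Oc1ccc(-n2cc(C#N)cn2)cc1)c1ccc(C(=O)NCCC(=O)O)cc1` gives 1.2 and compound 2 `CCCC(Oc1ccc(-n2cc3c(n2)CCCC3)cc1)c1ccc(C(=O)NCCC(=O)O)cc1` gives 2.7, so compound 2 holds the higher of the two numbers measured so far. Compound 3 `CCCC(Oc1ccc(-n2cccn2)cc1)c1ccc(C(=O)NCCC(=O)O)cc1` has not yet been measured. It differs from compound 2 in one place: a group of 5 heavy atoms (3 carbon, 2 nitrogen; one five-membered aromatic ring with 2 hetero atoms) in place of a group of 9 heavy atoms (7 carbon, 2 nitrogen; one five-membered aromatic ring with 2 hetero atoms, one six-membered non-aromatic ring of carbon only), on an aromatic carbon. The six-membered non-aromatic ring of carbon only leaves, while the five-membered aromatic ring stays. Going by the values given here, one measured step bears on this: a number 1.50 log units higher from compound 1 to compound 2 (beyond the scatter). From the compounds shown here alone, that large step also brought in this ring, but the nitrile of compound 1 was lost in the same move, so the share of the ring alone is unknown. Compound 3 lacks the ring, so a clear fall in this assay is expected, somewhat smaller than that measured step. The expected change is a number 1.00 log units lower from compound 2 to compound 3 (beyond the scatter). Compound 3 is therefore estimated at 1.7, with an expected range from 1.3 to 2.1.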

Compound 3, distribution coefficient: 1.7
Beside the measured number, compound 3's estimate shows no gap at the digits printed; the range from low to high includes it.
By their numbers in this assay, from the lowest: compound 1; then compound 3; then compound 2.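

Compound 3, with the plain 1H-pyrazol-1-yl group at this position, separates two changes that were combined in the earlier comparison. In this assay, hydrogen in place of the nitrile gives a number 0.50 log units higher from compound 1 to compound 3 (beyond the scatter), while losing the six-membered ring of carbon only gives a number 1.00 log units lower from compound 2 to compound 3 (beyond the scatter), so each change on its own moves the number beyond the scatter, and the ring accounts for the larger part. Nothing measured here explains why either change has this effect.

The compounds shown leave open where a single small group on the pyrazole, such as a methyl or a chlorine, would fall in this assay. They also leave open whether a triazole in place of the pyrazole would change the number.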